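From trifluoromethyl to fluoro: estimating compound 3

The compounds below may be only part of what the source reports. "The series", "measured", "known", "first", "only" and "open" are said of these compounds alone.

- compound 1 `O=C(/C=C/c1ccc(C(F)(F)F)cc1)Nc1nnc(-c2ccc(Br)cc2)s1`: 4.68 ug/mL
- compound 2 `O=C(/C=C/c1ccc(C(F)(F)F)cc1)Nc1nnc(-c2ccccc2)s1`: 1.78 ug/mL

Among the measured compounds shown here, in a functional assay on A549 cells (Homo sapiens) for antiproliferative activity, read by MTT assay, with a stated time of 48 h (on this read-out lower numbers stand for stronger inhibition and higher numbers for weaker inhibition), compound 1 gives 4.68 ug/mL, the higher of the two numbers so far. Compound 3 `O=C(/C=C/c1ccc(F)cc1)Nc1nnc(-c2ccc(Br)cc2)s1` has fluoro in place of trifluoromethyl on an aromatic carbon. For the measured compounds named here, the only measured step, a 2.6-fold lower number from compound 1 to compound 2 (0.42 log units; beyond the scatter), is modest and replaces bromo with hydrogen, a different change, so no measurement tests this swap directly. No step beyond the scatter is therefore expected in this assay, and no direction can be argued with confidence. The estimated step is a 1.0-fold lower number from compound 1 to compound 3 (0.02 log units; within the scatter). For compound 3 the expected value is 4.5 ug/mL, with an estimated range from 1.6 ug/mL to 12 ug/mL.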

Compound 3, half-maximal inhibitory concentration: 2.83 ug/mL
For compound 3 the middle estimate is 1.6-fold (0.20 log units) above the measured one, and the stated range covers the measured number.
By their numbers in this assay, from the lowest: compounds 2, 3 and 1 (each within the scatter of the next, the first and the last beyond it).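

In this assay, replacing trifluoromethyl with fluoro on this aromatic carbon gives a 1.7-fold lower number from compound 1 to compound 3 (0.22 log units; within the scatter) and so shows no clear change. The entering group has fewer heavy atoms, yet here, with bromo on the other side of the molecule, the two groups cannot be told apart. No measured evidence bears on this result.

On these data alone, whether a methoxy group or an amine at this position would move the number beyond the scatter remains open. So does whether the swap would give the same result on compound 2, which has hydrogen in place of bromo.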